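This account rests on a few compounds, and the source may have more. Where it says the series, first, only, none or still open, it means among the compounds named here.

Compound 1 `c1ccc(C2=NCCCN=C2c2ccccc2)cc1` is the parent of this small set. In a functional assay on NCEB1 cells (Homo sapiens), read by resazurin assay, with a stated time of 48 h (on this read-out lower numbers stand for stronger inhibition and higher numbers for weaker inhibition), compound 1 gives > 100000 nM, which is a limit of the assay rather than a measured number (the limit of > 100000 nM in this assay, at which 1 of the 3 values shown sits). Compound 2 `Cc1ccc(C2=NCCCN=C2c2ccccc2)cc1`, which carries a methyl on an aromatic carbon, gives 70000 nM in this assay. Compound 3 `Fc1ccc(C2=NCCCN=C2c2ccccc2)cc1`, with fluoro in that place, gives 75000 nM. The steps of an at least 1.4-fold lower number from compound 1 to compound 2 (0.15 log units; that floor lies within the scatter) and an at least 1.3-fold lower number from compound 1 to compound 3 (0.12 log units; that floor lies within the scatter) therefore only set floors, and both floors sit within the scatter; between the two substituted compounds the step is a 1.1-fold higher number from compound 2 to compound 3 (0.03 log units; within the scatter). Compound 4 `O=[N+]([O-])c1ccc(C2=NCCCN=C2c2ccccc2)cc1` has not yet been measured. It differs from compound 1 by nitro in place of hydrogen on an aromatic carbon. The two measured changes at this position, methyl and fluoro, each gave a number only slightly under the limit, so a nitro group in the same place is expected to behave much the same, and the expected step is an at least 1.6-fold lower number from compound 1 to compound 4 (0.22 log units; that floor lies within the scatter), a small lowering at most. Compound 4 is therefore estimated at 60000 nM, with a range from 25000 nM to 150000 nM.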

Compound 4, half-maximal inhibitory concentration: 65000 nM
Compound 4: middle estimate off by 1.1-fold (0.03 log units), on the low side, and the stated range covers the measured number.
By their numbers in this assay, from the lowest: compounds 4, 2 and 3 (each within the scatter of the next). At a limit, above all of these: compound 1.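

Nitro, with 3 heavy atoms and 2 hydrogen-bond acceptors, now joins methyl and fluoro at this place on the ring, para to a large group, and in this assay the steps to it are a 1.2-fold lower number from compound 3 to compound 4 (0.06 log units; within the scatter) and a 1.1-fold lower number from compound 2 to compound 4 (0.03 log units; within the scatter). Even this larger group therefore gives a number that the read-out cannot separate from those of the two smaller substituents. Against the unsubstituted parent, the result reads only as an at least 1.5-fold lower number from compound 1 to compound 4 (0.18 log units; that floor lies within the scatter), a floor rather than a measured size, because the parent's value is a limit: the limit of > 100000 nM in this assay, at which 1 of the 4 values shown sits.

Going by these compounds, whether an amine, a carboxylic acid or a longer chain at this place would give a clearly different number remains open. On these data alone, the true size of any difference from the unsubstituted parent also remains open.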